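The source may hold more compounds than are shown below. What is called first, only, known or untested is meant among the compounds shown, and "the series" means these compounds.

In an ADME assay on MT4 cells (Homo sapiens) for cytotoxicity, read by MTT assay (a lower number here means that less compound is tolerated, a higher number that more compound is tolerated), compound 2 `Cc1c(Cc2c(F)cccc2F)nc(SCc2cccnc2)[nH]c1=O` stands at > 70000 nM, which is a limit and not a number. Compound 1 `Cc1ccc(CSc2nc(Cc3c(F)cccc3F)c(C)c(=O)[nH]2)c(C)c1` gives > 65000 nM, also only a limit. Neither compound therefore offers a number to build on.

Compound 3 `Cc1c(Cc2c(F)cccc2F)nc(SCc2ccncc2)[nH]c1=O` keeps the rest of compound 2 and differs in one place: pyridin-4-yl in place of pyridin-3-yl on a saturated chain carbon bound to a sulfur. This places pyridin-4-yl in place of pyridin-3-yl on a saturated chain carbon bound to a sulfur, and the two compounds have the same atoms, joined differently.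

Going by the values given here, the only measured step bearing on this change is a step that the two limits leave unreadable from compound 1 to compound 2. No step beyond the scatter is expected in this assay, and no direction can be assigned, since a step that the two limits leave unreadable from compound 1 to compound 2 gives no size to carry over.

The expected step is a number no higher from compound 2 to compound 3 (the limit leaves the size open). For compound 3 the estimate is 70000 nM, with an expected range of 30000 nM to 150000 nM.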

Compound 3, half-maximal cytotoxic concentration: > 70000 nM
Compound 3 was reported as a limit; the forecaster's own chance of this, stated with the estimate: 75%; the middle value sits exactly at the limit.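

Going by these compounds alone, compound 1, compound 2 and compound 3 all stand only as limits in this assay, so no step among them can be read. The compounds shown leave open at what concentration each becomes cytotoxic, and whether exchanging pyridin-3-yl, pyridin-4-yl and 2,4-dimethylphenyl changes that concentration.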